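Amine chain change on the shared core: working notes

A few compounds are considered here, and "the series" means these few. Any claim that something is new, unique, unknown or untested is made for them only; others in the source may bear on it.

compound 1 `CCCOc1c(-c2cc(OC)c(OC)c(OC)c2)oc2ccccc2c1=O` gives 2800 nM
compound 2 `CCCCOc1c(-c2cc(OC)c(OC)c(OC)c2)oc2ccccc2c1=O` gives > 50000 nM as a limit of the assay
compound 3 `CCCN(CCC)CCCCOc1c(-c2cc(OC)c(OC)c(OC)c2)oc2ccccc2c1=O` gives 35800 nM

In a functional assay on DU-145 cells (Homo sapiens) for antiproliferative activity, read by WST assay, with a stated time of 3 days (a lower number here means a stronger inhibitor, a higher number a weaker inhibitor), compound 3 at 35800 nM holds the higher of the two actual numbers. The gap to the other actual number is a 13-fold higher number from compound 1 to compound 3 (1.11 log units; beyond the scatter) and lies beyond the scatter.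

Compound 4 `CCCCN(CCCC)CCCCCOc1c(-c2cc(OC)c(OC)c(OC)c2)oc2ccccc2c1=O` differs from compound 3 by (dibutylamino)methyl in place of dipropylamino on a saturated chain carbon, four bonds along the chain from an oxygen on an aromatic ring with (dibutylamino)methyl in place of dipropylamino on a saturated chain carbon, four bonds along the chain from an oxygen on an aromatic ring.

Going by the values given here, two measured steps bear on this change. Extending the chain gave an at least 17-fold higher number from compound 1 to compound 2 (1.25 log units; beyond the scatter) and adding the amine gave an at least 1.3-fold lower number from compound 2 to compound 3 (0.14 log units; that floor lies within the scatter) with a floor within the scatter. Among the compounds with values here, no measured step varies the amine's alkyl groups. In this assay compound 4 is therefore expected to stay near compound 3, with no step beyond the scatter, although a limit remains possible. The estimated change is a 1.4-fold lower number from compound 3 to compound 4 (0.16 log units; within the scatter) and stays within the scatter. Compound 4 is expected at 25000 nM with an estimated range from 5000 nM to 50000 nM in this series.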

Compound 4, half-maximal inhibitory concentration: > 50000 nM
Compound 4 was reported as a limit; the forecaster's own chance of this, stated with the estimate: 25%; middle value at least 2.0-fold (0.30 log units) from the limit.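

In this assay compound 4 gives > 50000 nM, which is a limit of the assay and not a number. The change to (dibutylamino)methyl gives an at least 1.3-fold higher number from compound 3 to compound 4 (0.14 log units; that floor lies within the scatter), so the data do not separate compound 4 from compound 3, while the distance from the propyl ether remains large, with an at least 17-fold higher number from compound 1 to compound 4 (1.25 log units; beyond the scatter). The step between compound 2 and compound 4 cannot be read, and this limit now holds for both compounds: the limit of > 50000 nM in this assay, at which 2 of the 4 values shown sit.

Going by these compounds, it remains open whether the chain length or the alkyl groups on the amine carry the step from compound 3 to compound 4, as that change alters both at once. Also open, on these data alone, is how a morpholine, a piperidine or a carboxylic acid in the same place would read against compound 1 at 2800 nM.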